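Second fluoro on the anilide: cytotoxicity outlook for compound 4

This account rests on a few compounds, and the source may have more. Where it says the series, first, only, none or still open, it means among the compounds named here.

The measured compounds:
compound 1, `Cc1nc(C(NC(=O)C(=O)Nc2ccc(Cl)cc2)C2CCCCN2)sc1CO`, in an ADME assay on TZM-b1 cells (Homo sapiens) for cytotoxicity, read by XTT assay, with a stated time of 3 days (a higher number here means that more compound is tolerated, a lower number that less compound is tolerated), gives > 22000 nM, which is a limit of the assay.
compound 2, `CC(=O)c1ccc(NC(=O)C(=O)NC(c2nc(C)c(CO)s2)C2CCCCN2)cc1`, in this assay gives > 86000 nM, also a limit.
compound 3, `Cc1nc(C(NC(=O)C(=O)Nc2ccc(F)cc2)C2CCCCN2)sc1CO`, in this assay gives > 90000 nM, again a limit.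

Compound 3 therefore stands at a limit, and the other two values shown are limits as well, so no ordering among the three can be read. The steps a step that the two limits leave unreadable from compound 1 to compound 3, a step that the two limits leave unreadable from compound 1 to compound 2 and a step that the two limits leave unreadable from compound 2 to compound 3 are all unreadable, because each pair sits at limits (the limit of > 22000 nM in this assay, at which 1 of the 3 values shown sits), the limit of > 86000 nM in this assay, at which 1 of the 3 values shown sits, and (the limit of > 90000 nM in this assay, at which 1 of the 3 values shown sits).

Compound 4, `Cc1nc(C(NC(=O)C(=O)Nc2ccc(F)cc2F)C2CCCCN2)sc1CO`, differs from compound 3 by fluoro in place of hydrogen on an aromatic carbon. Among the measured compounds shown here, no measured step bears on this change in a readable way, and every value shown is a limit. On that basis compound 4 is expected to remain at a limit in this assay, with the step of a number no higher from compound 3 to compound 4 (the limit leaves the size open) expected to be none beyond the scatter. The estimate for compound 4 is 90000 nM, within 30000 nM to 200000 nM, most likely reported only as a limit.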

Compound 4, half-maximal cytotoxic concentration: > 87000 nM
Compound 4 ended at the assay's limit; the forecaster's own chance of this, stated with the estimate: 85%; the middle value is on the limit's open side.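

In this assay, among the compounds shown here, compound 4 gives > 87000 nM, which is a limit of the assay, and no step to it from compound 1, compound 2 or compound 3 can be read. The compounds shown leave open at what concentration any of the four becomes cytotoxic.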